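Working notes: chain-end azole change from compound 3

The source may report more compounds than this note shows. Statements on the series, on what has been measured and on what is new or still open speak of the compounds shown alone.

Values in a functional assay on K562 cells (Homo sapiens) for antiproliferative activity, read by MTT assay, with a stated time of 48 h (on this read-out lower numbers stand for stronger inhibition and higher numbers for weaker inhibition), so far:
- compound 1 `Cn1cc(C2=C(c3nn(CCCn4cncn4)c4ncccc34)C(=O)N(c3ccccc3)C2=O)c2ccccc21` gives > 100000 nM (a limit of the assay, not a number)
- compound 2 `Cn1cc(C2=C(c3nn(CCCN4CCCCC4)c4ncccc34)C(=O)N(c3ccccc3)C2=O)c2ccccc21` gives 3790 nM
- compound 3 `Cn1cc(C2=C(c3nn(CCCn4cccc4)c4ncccc34)C(=O)NC2=O)c2ccccc21` gives 21600 nM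

For the measured compounds named here, of the two values that are numbers, the one of compound 3 stands higher on this read-out: compound 3 gives 21600 nM and compound 2 gives 3790 nM.

Compound 4 `Cn1cc(C2=C(c3nn(CCn4ccnc4)c4ncccc34)C(=O)NC2=O)c2ccccc21` carries 1H-imidazol-1-yl in place of (1H-pyrrol-1-yl)methyl on a saturated chain carbon, two bonds along the chain from an aromatic nitrogen.

Going by the values given here, only one measured step bears on this change: an at least 26-fold lower number from compound 1 to compound 2 (1.42 log units; beyond the scatter). That step is large, so a swap at the chain end can move the number in this assay strongly. However, it involves different groups on a different core and gives no direction for the present change, so the margin stays wide.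

An estimated step of a 1.1-fold lower number from compound 3 to compound 4 (0.03 log units; within the scatter) is expected, which stays within the usual scatter.

Compound 4 is expected at 20000 nM, with an estimated range from 5000 nM to 80000 nM.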

Compound 4, half-maximal inhibitory concentration: > 100000 nM
Compound 4 ended at the assay's limit; the forecaster's own chance of this, stated with the estimate: 15%; at least 5.0-fold (0.69 log units) between middle value and limit.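

For the compounds shown here, this is the first chain-end change measured on this core, and it has a direction: in this assay the move from 3-(1H-pyrrol-1-yl)propyl to 2-(1H-imidazol-1-yl)ethyl gives an at least 4.6-fold higher number from compound 3 to compound 4 (0.66 log units; beyond the scatter), so activity here does not survive this swap. The earlier compounds shown here gave a size for a chain-end change but no direction for this one. The step is only a lower bound, because compound 4 stands at a limit of the assay and not at a number: the limit of > 100000 nM in this assay, at which 2 of the 4 values shown sit.

The change alters the ring and the chain length together, and the compounds shown cannot separate the two. From the compounds shown here alone, a 3-(1H-imidazol-1-yl)propyl or 2-(1H-pyrrol-1-yl)ethyl end on this core would do so, and a dimethylamino group or a carboxylic acid at the chain end also remains open.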